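Tert-Butyl for Ethyl on the Aromatic Ring

The source may hold more compounds than are shown below. What is called first, only, known or untested is meant among the compounds shown, and "the series" means these compounds.

Of the compounds shown here, three have so far been measured in a functional assay on K562 cells (Homo sapiens) for inhibition; on this read-out higher numbers stand for weaker inhibition and lower numbers for stronger inhibition. Compound 1 `O=C1C=CC(OCC(F)(F)F)N1c1cc(Cl)cc(Cl)c1` gives 1640 nM, compound 2 `O=C1C=CC(OCC(F)(F)F)N1c1cc(F)cc(F)c1` gives 520 nM, and compound 3 `CCc1ccc(N2C(=O)C=CC2OCC(F)(F)F)cc1` gives 4470 nM, the highest of the three numbers and beyond the scatter of both others. Compound 4 `CC(C)(C)c1ccc(N2C(=O)C=CC2OCC(F)(F)F)cc1` differs from compound 3 in one place: tert-butyl in place of ethyl on an aromatic carbon. Among the measured compounds shown here, no pair of measured compounds shows a change of this kind, so there is nothing to set the size or direction of the step against. The step expected from compound 3 to compound 4 in this assay is a 1.2-fold higher number from compound 3 to compound 4 (0.09 log units; within the scatter), that is, no change beyond the scatter, with a wide range around it. Compound 4 is accordingly estimated at 5500 nM, between 1800 nM and 17000 nM.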

Compound 4, half-maximal inhibitory concentration: 70 nM
Beside the measured number, compound 4's estimate is 79-fold (1.90 log units) above it, outside the stated range (below it).
By their numbers in this assay, from the lowest: compound 4; then compound 2; then compound 1; then compound 3.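

In this assay, among the compounds shown here, the aromatic carbon para to a large group proves highly sensitive to the group it carries: tert-butyl in place of ethyl gives a 64-fold lower number from compound 3 to compound 4 (1.81 log units; beyond the scatter) and sets the first one-place step in this set. The change brings in no ring, no hydrogen-bond donor or acceptor and no net charge. As far as these compounds go, whether this gain needs tert-butyl itself stays open, as an isopropyl group, a straight butyl chain or a cyclopropyl ring at this carbon could show. No measurement shown here accounts for the size of the step.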